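Compound 2 to compound 4: one more chloro, another pattern

A few compounds are considered here, and "the series" means these few. Any claim that something is new, unique, unknown or untested is made for them only; others in the source may bear on it.

In a functional assay on HCT-116 cells (Homo sapiens) for antiproliferative activity, read by MTT assay, with a stated time of 72 h (on this read-out higher numbers stand for weaker inhibition and lower numbers for stronger inhibition), the measured compounds read as follows:
compound 1 (`NC1=NC2(CCSCC2)N(OCCCOc2cccc(Cl)c2)C(N)=N1`) 1 nM
compound 2 (`NC1=NC2(CCOCC2)N(OCCCOc2cccc(Cl)c2Cl)C(N)=N1`) 5 nM
compound 3 (`NC1=NC2(CCSCC2)N(OCCCOc2cccc(Cl)c2Cl)C(N)=N1`) 1 nM

Compound 2 has the highest number of the three, and the numbers of compound 1 and compound 3 both lie lower, beyond the scatter. Compound 4 (`NC1=NC2(CCOCC2)N(OCCCOc2cc(Cl)c(Cl)cc2Cl)C(N)=N1`) keeps the core of compound 2 but carries 2,4,5-trichlorophenyl in place of 2,3-dichlorophenyl on an oxygen on a saturated carbon. Within the data shown here, only one measured step bears on this change. It is chloro in place of hydrogen on an aromatic carbon, and it shows no change at the digits printed from compound 1 to compound 3 (within the scatter) on the core of compound 1. That step is an imperfect guide, since it was measured on another core and the exchange in compound 4 is not the same one. Among the measured compounds shown here, no step of this kind has been measured on the core of compound 2. In this assay no step beyond the scatter is therefore expected, and the estimate amounts to no change at the digits printed from compound 2 to compound 4 (within the scatter) for this exchange. Compound 4 is expected at 5 nM with an estimated range from 1.5 nM to 15 nM in this measurement.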

Compound 4, half-maximal inhibitory concentration: 2750 nM
For compound 4 the middle estimate is 550-fold (2.74 log units) below the measured one, outside the stated range (above it).
By their numbers in this assay, from the lowest: compounds 1 and 3 (each within the scatter of the next); then compound 2; then compound 4.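

In this assay, among these compounds, the exchange of 2,3-dichlorophenyl for 2,4,5-trichlorophenyl on an oxygen on a saturated carbon brings a 550-fold higher number from compound 2 to compound 4 (2.74 log units; beyond the scatter), a large step that makes this place far more sensitive than the earlier compounds suggested. Among the compounds shown here, until now the only step at this place was no change at the digits printed from compound 1 to compound 3 (within the scatter), measured on the core of compound 1, and taken alone it gave no sign that the chlorine pattern on the phenyl ring could matter; the new step shows that on the core of compound 2 the pattern matters a great deal. No measurement at hand bears on what lies behind a step of this size.

Because the entering group differs from the leaving one both in its number of chlorines and in their pattern, the compounds shown cannot tell which of the two carries the step, or whether the same exchange would act alike on the core of compound 1. Going by these compounds, it also stays open how this place would respond to a phenyl ring bearing methoxy or fluoro in place of chloro, or to a longer chain before the oxygen.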